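From Amide to Ester on a Shared Core

This account rests on a few compounds, and the source may have more. Where it says the series, first, only, none or still open, it means among the compounds named here.

Compound 1 `CCNC(=O)c1cnc(Oc2ccc3c(c2)B(O)OC3)cn1`: 79900 nM
Compound 2 `CN(C)C(=O)c1cnc(Oc2ccc3c(c2)B(O)OC3)cn1`: > 100000 nM

In an ADME assay on Jurkat cells (Homo sapiens) for cytotoxicity, read by MTT assay, with a stated time of 72 h (on this read-out lower numbers stand for stronger inhibition and higher numbers for weaker inhibition), compound 2 reads > 100000 nM, which is a limit and not a number. Within the data shown here, the only measured step is an at least 1.2-fold higher number from compound 1 to compound 2 (0.09 log units; that floor lies within the scatter), and it exchanges one amide substituent for another. Compound 3 `CC(C)OC(=O)c1cnc(Oc2ccc3c(c2)B(O)OC3)cn1` instead carries isopropoxy in place of dimethylamino on a carbonyl carbon. Among the measured compounds shown here, no measured step covers this change, so the nearest guide is compound 1 at 79900 nM. A small move toward a lower number is therefore expected, namely an at least 1.4-fold lower number from compound 2 to compound 3 (0.15 log units; that floor lies within the scatter). For compound 3 the estimate is 70000 nM, with an expected range of 25000 nM to 100000 nM.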

Compound 3, half-maximal inhibitory concentration: > 100000 nM
Compound 3 ended at the assay's limit; the forecaster's own chance of this, stated with the estimate: 40%; middle value at least 1.4-fold (0.15 log units) from the limit.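

Compound 3 shows that the carbonyl carbon can carry an oxygen-linked isopropoxy group as well as an amide nitrogen without the reading in this assay leaving the top of its range. Isopropoxy in place of ethylamino gives an at least 1.2-fold higher number from compound 1 to compound 3 (0.09 log units; that floor lies within the scatter), so this change separates nothing beyond the scatter. The step between the ester and the dimethylamide cannot be read, since both values are limits: the limit of > 100000 nM in this assay, at which 2 of the 3 values shown sit.

As far as these compounds go, how far either compound lies past that limit stays open. So does whether a carboxylic acid or a longer chain on this carbonyl carbon would give a measurable value.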